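This account rests on a few compounds, and the source may have more. Where it says the series, first, only, none or still open, it means among the compounds named here.

Compound 1 `COc1ccc(OCC(=O)N2CCN(c3ccc(C(F)(F)F)cc3[C@@H](N)CC(C)C)CC2)cc1` gives 3800 nM in an assay on HEK293 cells for displacement of a labelled ligand from Melanocortin receptor 4 (Homo sapiens); a higher number here means a weaker inhibitor, a lower number a stronger inhibitor. Compound 2 `CC(C)C[C@H](N)c1cc(C(F)(F)F)ccc1N1CCN(C(=O)C(C)Cc2ccc(Cl)cc2)CC1` gives 47 nM. Compound 3 `CC(C)C[C@H](N)c1cc(C(F)(F)F)ccc1N1CCN(C(=O)CNc2ccccc2)CC1` gives 3600 nM.

Compound 2 has the lowest number of the three: an 81-fold lower number from compound 1 to compound 2 (1.91 log units; beyond the scatter), and a 77-fold higher number from compound 2 to compound 3 (1.88 log units; beyond the scatter). Compound 4 `CCOc1cccc(CC(C)C(=O)N2CCN(c3ccc(C(F)(F)F)cc3[C@@H](N)CC(C)C)CC2)c1` differs from compound 2 in one place: 3-ethoxyphenyl in place of 4-chlorophenyl on a saturated chain carbon, two bonds along the chain from a carbonyl carbon. Among the compounds with values here, the two measured steps that touched this region each replaced the whole group on the carbonyl carbon, and both were large; no measured step changes only the aromatic ring while keeping the rest of that group, so they give only a loose guide. The change here is smaller in kind, so a modest step in this assay is expected, most likely toward a somewhat higher number. Compound 4 is therefore estimated at 120 nM, with a range from 30 nM to 500 nM, meaning an expected step of a 2.6-fold higher number from compound 2 to compound 4 (0.41 log units; beyond the scatter).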

Compound 4, inhibition constant: 2200 nM
For compound 4 the middle estimate is 18-fold (1.26 log units) below the measured one; the whole stated range lies below it.
By their numbers in this assay, from the lowest: compound 2; then compounds 4, 3 and 1 (each within the scatter of the next).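

The aromatic ring alone matters greatly at this position: with the rest of the group on the carbonyl carbon kept, 3-ethoxyphenyl in place of 4-chlorophenyl gives a 47-fold higher number from compound 2 to compound 4 (1.67 log units; beyond the scatter). This one swap brings compound 4 level with the two compounds carrying other groups, as a 1.6-fold lower number from compound 3 to compound 4 (0.21 log units; within the scatter) and a 1.7-fold lower number from compound 1 to compound 4 (0.24 log units; within the scatter) show, so the 1-benzylethyl frame alone does not secure the low number of compound 2. Nothing available explains this step.

The compounds shown cannot separate the effect of removing chlorine from that of adding ethoxy or moving the substituent. A 3-chlorophenyl or 4-ethoxyphenyl group at this place would help to separate them.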